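Pendant aryl substituent and inhibition of paw edema

The compounds below may be only part of what the source reports. "The series", "measured", "known", "first", "only" and "open" are said of these compounds alone.

The series shares one core and varies the aryl group on it. Compound 1 `O=C(O)c1cc(-n2c(-c3ccccc3)cc3c2CCCC3)ccc1O` carries a plain phenyl; in a functional assay on the whole organism (strain Wistar) for inhibition, with Rattus norvegicus as the target, read by paw edema, with stated times of 30 min and 3 h, at a dose of 200 mg/kg by the oral route (on this read-out lower numbers stand for less inhibition and higher numbers for more inhibition at the one dose given (going by the name of the read-out)), compound 1 gives >= 60%, which is a limit of the assay rather than a number (the limit of >= 60% in this assay, at which 1 of the 3 values shown sits). Compound 2 `O=C(O)c1cc(-n2c(-c3ccc(Cl)c(Cl)c3)cc3c2CCCC3)ccc1O` gives 0%, and compound 3 `O=C(O)c1cc(-n2c(-c3ccc(O)cc3)cc3c2CCCC3)ccc1O` gives 20%. Among the two numbers shown, compound 3 stands highest, with compound 2 nearest, as seen in the step of a number 20 percentage points higher from compound 2 to compound 3 (beyond the scatter). The two steps away from compound 1 are both large: a number at least 60 percentage points lower from compound 1 to compound 2 (beyond the scatter) and a number at least 40 percentage points lower from compound 1 to compound 3 (beyond the scatter).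

Compound 4 `N#Cc1ccc(-c2cc3c(n2-c2ccc(O)c(C(=O)O)c2)CCCC3)cc1` is not yet measured. It differs from compound 3 by cyano in place of hydroxy on an aromatic carbon. For the measured compounds named here, no measured step touches a cyano group; the steps that bear on the change are those on the same phenyl ring, where 3,4-dichlorophenyl in place of phenyl and hydroxy in place of hydrogen both lowered the read-out, while 4-hydroxyphenyl in place of 3,4-dichlorophenyl raised it modestly. A substituent on this ring has so far stayed below the plain phenyl of compound 1. Compound 4 is therefore expected to give 25%, between 0% and 55%. The expected step of a number 5 percentage points higher from compound 3 to compound 4 (within the scatter) stays within the scatter.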

Compound 4, a percentage reported as inhibition, in the whole organism at one dose (the size of the read-out at that dose, not a potency): 0%
The estimate for compound 4 lay 25 percentage points above the measured number; the range from low to high includes it.
By their numbers in this assay, from the lowest: compounds 2 and 4 (each within the scatter of the next); then compound 3. At a limit, above all of these: compound 1.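

Hydroxy and cyano do not read alike at this place, on an aromatic carbon para to a large group: this assay shows a number 20 percentage points lower from compound 3 to compound 4 (beyond the scatter), while 4-cyanophenyl and 3,4-dichlorophenyl cannot be told apart, with no change at the digits printed from compound 2 to compound 4 (within the scatter). Of the three substituted rings shown, only the 4-hydroxyphenyl ring therefore stands apart from the others, and cyano in place of hydrogen gives a number at least 60 percentage points lower from compound 1 to compound 4 (beyond the scatter), which leaves all three substituted rings under the plain phenyl, with no compound shown going against that. The value of compound 1 is a limit, not a number, so the full size of these drops from the plain phenyl stays unfixed: the limit of >= 60% in this assay, at which 1 of the 4 values shown sits.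

On these data alone, whether any group on this ring can keep the read-out near that of the plain phenyl remains open, and a reading at one dose gives no potency to separate the compounds that sit together at the bottom of the range. An amine, a carboxylic acid or a longer chain such as ethoxy at the same place would show whether the higher reading of the 4-hydroxyphenyl ring is particular to hydroxy.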